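The source may hold more compounds than are shown below. What is called first, only, known or untested is meant among the compounds shown, and "the series" means these compounds.

Measured so far:
Compound 1 `CCOC(=O)Nc1ccc([Se][Se]c2ccc(NC(=O)OCC)cc2)cc1`: 16100 nM in an ADME assay on BEAS-2B cells (Homo sapiens) for cytotoxicity, read by MTT assay, with a stated time of 72 h; a higher number here means a weaker inhibitor of growth, a lower number a stronger inhibitor of growth
Compound 2 `CC(C)COC(=O)Nc1ccc([Se]C#N)cc1`: 26900 nM in this assay

Of the two numbers, that of compound 2 is the higher, yet the gap to compound 1 is within the scatter, so the two cannot be told apart. Compound 3 `N#C[Se]c1ccc(NC(=O)OCc2ccccc2)cc1` differs from compound 2 by a single change: phenyl in place of isopropyl on a saturated chain carbon bound to an oxygen next to a carbonyl group. For the measured compounds named here, no step between measured compounds bears on this change, so no shift beyond the scatter is expected in either direction. Compound 3 is therefore expected to give 25000 nM in this assay, within 8000 nM to 80000 nM. For compound 3 this estimate means a step of a 1.1-fold lower number from compound 2 to compound 3 (0.03 log units; within the scatter), which is expected to lie within the scatter.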

Compound 3, concentration for 50% growth inhibition: 100 nM
Compound 3: the middle estimate sits 250-fold (2.40 log units) above what was measured; the measured number lies below the stated range.
By their numbers in this assay, from the lowest: compound 3; then compounds 1 and 2 (each within the scatter of the next).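

In this assay, this place on a saturated chain carbon bound to an oxygen next to a carbonyl group proves highly sensitive: phenyl in place of isopropyl gives a 270-fold lower number from compound 2 to compound 3 (2.43 log units; beyond the scatter). The earlier compounds shown here could not show this, as no single-place step linked them. Nothing available explains the size of this step.

As far as these compounds go, it remains open whether the aromatic ring itself is required, or whether a cyclohexyl ring or a longer chain at this place would give a similar step. From the compounds shown here alone, whether a methoxy or chloro group on the phenyl ring would preserve the low number is also open.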